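A few compounds are considered here, and "the series" means these few. Any claim that something is new, unique, unknown or untested is made for them only; others in the source may bear on it.

Working notes on the series. Three compounds carry the shared core and a long unsaturated chain joined through different linkers, all measured in an assay on microsomes from intestinal mucosa for inhibition of acyl-CoA:cholesterol acyltransferase (Oryctolagus cuniculus); a higher number here means a weaker inhibitor, a lower number a stronger inhibitor. Compound 1 `CCCCCCCC/C=C\CCCCCCCC(=O)c1c(OC)cc(OC)cc1OC`, with a ketone linker, reaches only a limit of > 50000 nM in this assay. Compound 3 `CCCCCCCC/C=C\CCCCCCCCNCc1c(OC)cc(OC)cc1OC`, with a secondary amine linker, likewise reaches only a limit of > 100000 nM in this assay. Among the measured compounds shown here, compound 2 `CCCCCCCC/C=C\CCCCCCCCNC(=O)Nc1c(OC)cc(OC)cc1OC`, the urea, is the one member with a numeric result, giving 320 nM in this assay. It therefore stands alone on the numbers, compound 1 and compound 3 being held at limits (the limit of > 50000 nM in this assay, at which 1 of the 3 values shown sits, (the limit of > 100000 nM in this assay, at which 1 of the 3 values shown sits)).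

Compound 4 `CCCCCCCCCCCCCCCCCCNC(=O)Nc1c(OC)cc(OC)cc1OC` keeps the urea linker and the core of compound 2 and differs from it in a single place: decyl in place of dec-1-en-1-yl on a saturated chain carbon, eight bonds along the chain from an amide-type nitrogen. For the measured compounds named here, no measured pair in the set isolates such a change in the chain, so the size of the step has to be estimated without a direct precedent. The urea linker of compound 2 is retained, and compound 4 is expected to remain a numeric result rather than a limit. The chain change is expected to cost little, the expected step of a 1.9-fold higher number from compound 2 to compound 4 (0.27 log units; within the scatter) lying around the edge of the scatter, toward weaker inhibition. For compound 4 the expected value in this assay is 600 nM, with a range from 150 nM to 2500 nM.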

Compound 4, half-maximal inhibitory concentration: 900 nM
For compound 4 the middle estimate is 1.5-fold (0.18 log units) below the measured one, within the range that was stated.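

In this assay, among the compounds shown here, replacing dec-1-en-1-yl with decyl on a saturated chain carbon, eight bonds along the chain from an amide-type nitrogen, gives a 2.8-fold higher number from compound 2 to compound 4 (0.45 log units; beyond the scatter); this is the only pair that differs in the chain alone and the only one with a number at both ends. Removing this double bond therefore costs a modest but readable amount of inhibition, and with the urea linker kept, the fully saturated chain still gives a numeric result, with compound 4 at 900 nM. None of the information available on the series bears on why the saturated chain gives the higher number.

The compounds shown leave open whether the same change in the chain would have any readable effect with the ketone or secondary amine linker, as both of those compounds stand at limits. Also open, from the compounds shown here alone, is how a longer or shorter chain, a triple bond at the same place, or a double bond of the opposite geometry would compare with decyl and dec-1-en-1-yl on the urea linker.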